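The source may hold more compounds than are shown below. What is called first, only, known or untested is meant among the compounds shown, and "the series" means these compounds.

Of the compounds shown here, three have so far been measured in a functional assay on CHO-K1 cells for antagonist activity at cysteinyl leukotriene receptor 1 (Homo sapiens), read by fluorescence and calcium flux, with stated times of 30 min and 1 h; a lower number here means a stronger inhibitor, a higher number a weaker inhibitor. Compound 1 `Cc1c(CCCC(=O)O)c2cccc(/C=C/c3ccc(OCCCCc4ccccc4)cc3)c2n1CC(=O)O` gives 4.1 nM in this assay. Compound 2 `Cc1c(CCCC(=O)O)c2cccc(/C=C/c3ccc(OCCCCc4c(F)cc(F)c(F)c4F)cc3)c2n1CC(=O)O` gives 1.6 nM in this assay, and compound 3 `Cc1c(F)cccc1CCCCOc1ccc(/C=C/c2cccc3c(CCCC(=O)O)c(C)n(CC(=O)O)c23)cc1` gives 1.1 nM in this assay. The number for compound 3 is the lowest of the three shown, though its gap to compound 2 lies within the scatter and so the two cannot be told apart; only its gap to compound 1 lies beyond it. Compound 4 `Cc1c(CCCC(=O)O)c2cccc(/C=C/c3ccc(OCCCCc4cc(F)c(F)c(F)c4F)cc3)c2n1CC(=O)O` has not yet been measured in this assay. The change from compound 3 to compound 4 is 2,3,4,5-tetrafluorophenyl in place of 3-fluoro-2-methylphenyl on a saturated chain carbon, four bonds along the chain from an oxygen on an aromatic ring. Among the compounds with values here, two measured steps bear on this exchange. Starting from the plain phenyl, a tetrafluorophenyl gave a 2.6-fold lower number from compound 1 to compound 2 (0.41 log units; beyond the scatter) and the fluoro-methylphenyl gave a 3.7-fold lower number from compound 1 to compound 3 (0.57 log units; beyond the scatter), while the two substituted rings themselves differ by only a 1.5-fold lower number from compound 2 to compound 3 (0.16 log units; within the scatter). Since the two substituted rings end up so close to one another, replacing one with a tetrafluorophenyl of a different fluorine pattern is expected to shift the number little, and a step of about a 1.4-fold higher number from compound 3 to compound 4 (0.13 log units; within the scatter) is expected, within the scatter. Compound 4 is accordingly estimated at 1.5 nM, with a range from 0.7 nM to 3.5 nM.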

Compound 4, half-maximal inhibitory concentration: 0.8 nM
Compound 4: the middle estimate sits 1.9-fold (0.27 log units) above what was measured; low and high end bracket the measured number.
By their numbers in this assay, from the lowest: compounds 4, 3 and 2 (each within the scatter of the next); then compound 1.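

In this assay, the 2,3,4,5-tetrafluorophenyl on a saturated chain carbon, four bonds along the chain from an oxygen on an aromatic ring, cannot be told apart from the 3-fluoro-2-methylphenyl (a 1.4-fold lower number from compound 3 to compound 4 (0.14 log units; within the scatter)) or from the 2,3,4,6-tetrafluorophenyl (a 2.0-fold lower number from compound 2 to compound 4 (0.30 log units; within the scatter)), so this position accepts a second fluorine pattern without a change that can be read. Set against the plain phenyl, the new ring gives a step beyond the scatter (a 5.1-fold lower number from compound 1 to compound 4 (0.71 log units; beyond the scatter)), which makes it the third substituted ring shown to separate from phenyl, and none of the listed rings goes against this. No measurement is at hand that would explain these numbers.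

The compounds shown leave open whether a single fluorine or a single methyl on the phenyl would already separate from the plain phenyl, and whether a pyridine ring or a cyclohexyl ring could take the place of the substituted phenyl. They also leave open how a shorter or longer chain would behave with any of these rings at its end.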